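The compounds below may be only part of what the source reports. "The series", "measured", "known", "first", "only" and "open" are said of these compounds alone.

Of the compounds shown here, two have been measured in an assay on HEK293 cells for displacement of a labelled ligand from NPC1-like intracellular cholesterol transporter 1 (Homo sapiens) (a higher number here means a weaker inhibitor, a lower number a stronger inhibitor), so far. Compound 1, `CC(C)(C)c1ccc(C(=O)N2CCC3(CC2)C(=O)N(CC(=O)N2CCN(S(C)(=O)=O)CC2)CN3c2ccccc2)cc1`, gives 19000 nM in this assay. Compound 2, `CC(C)(C)OC(=O)NC1CCN(C(=O)CN2CN(c3ccccc3)C3(CCN(C(=O)c4ccc(C5CCCCC5)cc4)CC3)C2=O)CC1`, gives 4800 nM in this assay. Of these two numbers compound 1 has the higher one, and the gap to compound 2 lies beyond the usual scatter of such measurements, so compound 1 is the weaker binder of the pair.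

The next compound, compound 3, is `CC(C)(C)c1ccc(C(=O)N2CCC3(CC2)C(=O)N(CC(=O)NCCCCN)CN3c2ccccc2)cc1`. It differs from compound 1 in one place only: (4-aminobutyl)amino in place of 4-(methylsulfonyl)piperazin-1-yl on a carbonyl carbon. The two compounds share the same core, and the change sits at the end of the chain that carries the amide.

Among the measured compounds shown here, no measured pair in this set shows what such a change does, so there is no direct guide. Taken on its own, an exchange at the outer end of a side chain, with the rest of the molecule kept, is expected to move the number only modestly; the step from compound 1 to compound 3 is estimated as a 1.6-fold lower number from compound 1 to compound 3 (0.20 log units; within the scatter), leaning slightly toward a stronger inhibitor. Compound 3 is therefore expected to give about 12000 nM in this assay, with a range from 3500 nM to 40000 nM.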

Compound 3, half-maximal inhibitory concentration: 14500 nM
The estimate for compound 3 lay 1.2-fold (0.08 log units) below the measured number; low and high end bracket the measured number.
By their numbers in this assay, from the lowest: compound 2; then compounds 3 and 1 (each within the scatter of the next).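

In this assay, putting (4-aminobutyl)amino in place of 4-(methylsulfonyl)piperazin-1-yl on the carbonyl carbon gives a 1.3-fold lower number from compound 1 to compound 3 (0.12 log units; within the scatter) while the rest of the molecule stays the same. Among the compounds shown here, this is the first single-place comparison, and it shows that this position can accept two very different end groups without a change that can be told from ordinary measurement scatter: an open chain with hydrogen-bond donors reads the same as a ring with none and with a sulfonyl group. No measurement available here accounts for this similarity.

Because the ring, the sulfonyl group and the chain's terminal amine all differ within this one exchange, the pair cannot show whether any single feature matters on its own, or whether opposing contributions happen to cancel. A shorter or longer chain, a terminal carboxylic acid, or an acetamide in place of the terminal amine on the same core would test whether this position ever moves the number beyond the scatter.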